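Tert-Butyl in Place of Methyl on Compound 3

The source may report more compounds than this note shows. Statements on the series, on what has been measured and on what is new or still open speak of the compounds shown alone.

Of the compounds shown here, three have been measured in a functional assay on CHO-K1 cells for antagonist activity at C-X-C chemokine receptor type 3 (Homo sapiens), read by FLIPR, with a stated time of 10 min; on this read-out higher numbers stand for weaker inhibition and lower numbers for stronger inhibition. Compound 1 `Cc1ncc(-c2nc(C(F)(F)F)sc2N2CCN(C(=O)Cn3cnc4cccnc43)[C@H](C)C2)cn1` gives 3.6 nM, compound 2 `CCOc1ncc(-c2nc(C(F)(F)F)sc2N2CCN(C(=O)Cn3cnc(C(F)(F)F)n3)[C@H](C)C2)cn1` gives 3.8 nM, and compound 3 `Cc1ncc(-c2nc(C(F)(F)F)sc2N2CCN(C(=O)Cn3nc(C)nc3C)[C@H](C)C2)cn1` gives 19 nM, the highest of the three numbers. Among the measured compounds shown here, the step of a 5.3-fold higher number from compound 1 to compound 3 (0.72 log units; beyond the scatter) is the single measured change; compound 2 and compound 3 differ in more than one place, so only their two values can be compared. Compound 4 `Cc1nc(C)n(CC(=O)N2CCN(c3sc(C(F)(F)F)nc3-c3cnc(C(C)(C)C)nc3)C[C@H]2C)n1` arises from compound 3 by one change: tert-butyl in place of methyl on an aromatic carbon. For the measured compounds named here, no measured step touches this group alone, so nothing known bears directly on it. Compound 4 is therefore expected to give 19 nM, within 7 nM to 50 nM, an estimated step of no change at the digits printed from compound 3 to compound 4 (within the scatter) of no size beyond the scatter.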

Compound 4, half-maximal inhibitory concentration: 8.7 nM
Estimate against measurement, compound 4: 2.2-fold (0.34 log units) above, and the stated range covers the measured number.
By their numbers in this assay, from the lowest: compounds 1 and 2 (each within the scatter of the next); then compound 4; then compound 3.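

In this assay, going from 2-methylpyrimidin-5-yl to 2-(tert-butyl)pyrimidin-5-yl gives a 2.2-fold lower number from compound 3 to compound 4 (0.34 log units; beyond the scatter). Among the compounds shown here, this is the first one-place comparison at this position, and it shows that the larger tert-butyl group is tolerated here and even gives modestly stronger inhibition. No supporting data explain the gain. For the compounds shown here, with only two groups compared here, it remains open whether the number keeps falling with size. Isopropyl, cyclopropyl or an amine at this position could help to settle that.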